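A few compounds are considered here, and "the series" means these few. Any claim that something is new, unique, unknown or untested is made for them only; others in the source may bear on it.

Measured so far:
compound 1, `O=C(CN1CCC(c2ccccn2)CC1)Nc1c(Cl)cc(Cl)cc1Cl`: 45%
compound 2, `c1ccc(C2CCN(Cc3nc4ccccc4[nH]3)CC2)nc1`: 62%
compound 3, `Cc1cccc(NC(=O)CN2CCC(c3ccccc3)CC2)c1`: 37%

All three were tested in a functional assay on HEK293 cells for agonist activity at D(4) dopamine receptor (Homo sapiens), read by FLIPR; a lower number here means a smaller maximal response, a higher number a larger maximal response. Compound 3 shows the smallest of the three numbers, but its result lies within the usual scatter of that of compound 1, so the two cannot be told apart; compound 2 sits clearly above it, beyond the scatter. Compound 4, `Cc1cccc(NC(=O)CN2CCC(c3cccc(C#N)n3)CC2)c1`, has not yet been measured. It differs from compound 3 in one place: 6-cyanopyridin-2-yl in place of phenyl on a saturated ring carbon. Going by the values given here, no pair of measured compounds differs in exactly one place, so the size of such a step has not been seen directly in this set. The step from compound 3 to compound 4 is expected to be a number 5 percentage points higher from compound 3 to compound 4 (within the scatter), a small rise that may well stay within the scatter, partly because compound 1 gives 45% in this assay. For compound 4 the estimated value in this assay is 42%, with a likely range from 25% to 60%.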

Compound 4, largest response reached (reported as efficacy), in percent of the reference or control that the assay uses: 42%
Compound 4: the middle estimate sits on the measured number at the digits printed, within the range that was stated.
By their numbers in this assay, from the lowest: compounds 3, 4 and 1 (each within the scatter of the next); then compound 2.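

Going by these compounds alone, this is the first step in the set that can be read directly: in this assay, 6-cyanopyridin-2-yl in place of phenyl on a saturated ring carbon gives a change that stays within the scatter (a number 5 percentage points higher from compound 3 to compound 4 (within the scatter)). At this place, three ring bonds from the ring nitrogen, a larger group with a ring nitrogen, a nitrile and two hydrogen-bond acceptors gives a maximal response that cannot be told apart from that of the phenyl group, which has no such acceptors. No measurement shown here accounts for this result.

As far as these compounds go, it remains open whether the ring nitrogen or the nitrile has any effect of its own on the core of compound 3. From the compounds shown here alone, it is also open whether an amine or a carboxylic acid in place of the nitrile would keep the response in this range.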